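From 4-methoxyphenyl to 3-amino-4-methoxyphenyl: working notes

A few compounds are considered here, and "the series" means these few. Any claim that something is new, unique, unknown or untested is made for them only; others in the source may bear on it.

In a functional assay on K562 cells (Homo sapiens) for cytotoxicity, read by MTT assay, with a stated time of 5 days (a higher number here means a weaker inhibitor, a lower number a stronger inhibitor), compound 1 (`COc1ccc(Cn2nncc2-c2cc(OC)c(OC)c(OC)c2)cc1`) gives 8660 nM, the higher of the two exact numbers in the series. The nearest of these is compound 3 (`COc1ccc(Cn2nncc2-c2cc(OC)c(OC)c(OC)c2)cc1O`) at 1830 nM. Compound 2 (`COc1ccc(Cn2nncc2-c2cc(OC)c(OC)c(OC)c2)cc1Br`) gives > 10000 nM, which is a limit of the assay and not a number.

The next compound is compound 4 (`COc1ccc(Cn2nncc2-c2cc(OC)c(OC)c(OC)c2)cc1N`), which takes amino in place of hydrogen on an aromatic carbon of compound 1: amino in place of hydrogen on an aromatic carbon. The new group stands ortho to a methoxy group, where compound 2 carries bromo and compound 3 carries hydroxy.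

Within the data shown here, two measured steps bear on this change. The hydroxy step is a 4.7-fold lower number from compound 1 to compound 3 (0.68 log units; beyond the scatter). The bromo step is an at least 1.1-fold higher number from compound 1 to compound 2 (0.06 log units; that floor lies within the scatter), and it rests on the limit. Among the measured compounds shown here, the hydroxy step is the closer parallel for a small group carrying a hydrogen-bond donor, so a modest move to a lower number in this assay is expected, though with wide uncertainty, as no amino compound has been measured.

The expected step is a 4.3-fold lower number from compound 1 to compound 4 (0.64 log units; beyond the scatter).

For compound 4 the estimate is 2000 nM, with an expected range of 400 nM to 9000 nM.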

Compound 4, half-maximal inhibitory concentration: 730 nM
The estimate for compound 4 lay 2.7-fold (0.44 log units) above the measured number; the measured number falls inside the stated range.
By their numbers in this assay, from the lowest: compound 4; then compound 3; then compound 1. At a limit, above all of these: compound 2.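

In this assay, amino ortho to a methoxy group gives a 12-fold lower number from compound 1 to compound 4 (1.07 log units; beyond the scatter), a large step where the earlier hydroxy step was only modest, so this position can support a greater change than compounds 1 to 3 had shown. Amino and hydroxy also separate from each other, with a 2.5-fold lower number from compound 3 to compound 4 (0.40 log units; beyond the scatter), so the outcome here depends on which of these two groups is present and not only on hydrogen being replaced. The spread from bromo to amino is an at least 13-fold lower number from compound 2 to compound 4 (1.13 log units; beyond the scatter), and this is only a floor, since the value of compound 2 is a limit of the assay: the limit of > 10000 nM in this assay, at which 1 of the 4 values shown sits.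

The compounds shown leave open what the amino group contributes here, and whether a methylamino group, a dimethylamino group or an acetamide at the same place would keep the step, which would show whether the unsubstituted amino group is needed. They also leave open whether a fluoro or methyl group there would behave more like bromo or more like hydroxy, and whether the order of compound 4, compound 3 and compound 1 holds beyond this cell line.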